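This account rests on a few compounds, and the source may have more. Where it says the series, first, only, none or still open, it means among the compounds named here.

Compound 2, `CCN(CC)CCCCOc1ccc(/C=C/C(=O)Nc2ccccc2)cc1OC`, gives 1.59 in a physicochemical assay for lipophilicity, using the shake flask method, measured as octanol-water partition, at pH 7.4 (on this read-out higher numbers stand for higher lipophilicity and lower numbers for lower lipophilicity), the top of the two numbers recorded, although its nearest neighbour compound 1, `COc1cc(/C=C/C(=O)Nc2ccccc2)ccc1OCCCN(C)C`, gives 1.55 and the step of a number 0.04 log units higher from compound 1 to compound 2 (within the scatter) keeps the pair within the scatter. Compound 3, `COc1cc(/C=C/C(=O)Nc2ccccc2)ccc1OCCCCCN1CCCCC1`, differs from compound 2 by (piperidin-1-yl)methyl in place of diethylamino on a saturated chain carbon, four bonds along the chain from an oxygen on an aromatic ring. For the measured compounds named here, the single measured step, dimethylamino to (diethylamino)methyl, is the only guide, and it was flat; for the entry of a six-membered ring no measured step exists. Compound 3 is nevertheless expected to come out somewhat higher, by about a number 0.41 log units higher from compound 2 to compound 3 (beyond the scatter). The estimate for compound 3 is 2, with a range from 1.5 to 2.5.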

Compound 3, partition coefficient: 1.65
Beside the measured number, compound 3's estimate is 0.35 log units above it; the measured number falls inside the stated range.
By their numbers in this assay, from the lowest: compounds 1, 2 and 3 (each within the scatter of the next).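

In this assay, the entry of a six-membered non-aromatic ring as (piperidin-1-yl)methyl in place of diethylamino gives no separation (a number 0.06 log units higher from compound 2 to compound 3 (within the scatter)), and neither does 2-(piperidin-1-yl)ethyl in place of dimethylamino (a number 0.10 log units higher from compound 1 to compound 3 (within the scatter)). At this place on the chain, then, a ring amine and two open-chain amines all sit within the scatter of one another. No measurement offered here accounts for this. The compounds shown leave open whether a morpholine ring, a primary amine or a carboxylic acid at the chain end would separate from these three.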